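Swapping methyl for chloro on the benzoyl ring

The compounds below may be only part of what the source reports. "The series", "measured", "known", "first", "only" and "open" are said of these compounds alone.

Compound 2 `Cc1ccc(C(=O)OC2(C(=O)Nc3ccc([N+](=O)[O-])cc3)CCCCC2)cc1` gives 9.8 nM in a functional assay on MCF7 cells (Homo sapiens) for inhibition, read by MTT assay, with a stated time of 72 h (a lower number here means a stronger inhibitor, a higher number a weaker inhibitor), the lower of the two numbers recorded so far. Its nearest neighbour is compound 1 `O=C(OC1(C(=O)Nc2ccc([N+](=O)[O-])cc2)CCCCC1)c1ccc(C(F)(F)F)cc1`, which in this assay gives 27.1 nM; the change a 2.8-fold lower number from compound 1 to compound 2 (0.44 log units; beyond the scatter) came from methyl in place of trifluoromethyl on an aromatic carbon. Compound 3 `O=C(OC1(C(=O)Nc2ccc([N+](=O)[O-])cc2)CCCCC1)c1ccc(Cl)cc1` has not yet been measured. It differs from compound 2 by chloro in place of methyl on an aromatic carbon, that is, the same aromatic carbon now carries chloro. Going by the values given here, the only step measured so far, that from compound 1 to compound 2, concerns a different exchange at this position and was modest, so a large effect is not expected here. Compound 3 is estimated to fall close to compound 2, with the step of a 1.4-fold higher number from compound 2 to compound 3 (0.15 log units; within the scatter) likely within the usual scatter. The expected value for compound 3 is therefore 14 nM, with a plausible range from 5 nM to 40 nM.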

Compound 3, half-maximal inhibitory concentration: 15 nM
The estimate for compound 3 lay 1.1-fold (0.03 log units) below the measured number; low and high end bracket the measured number.
By their numbers in this assay, from the lowest: compounds 2, 3 and 1 (each within the scatter of the next, the first and the last beyond it).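

In this assay, the step of a 1.5-fold higher number from compound 2 to compound 3 (0.18 log units; within the scatter) and the step of a 1.8-fold lower number from compound 1 to compound 3 (0.26 log units; within the scatter) both lie within the scatter, so at this aromatic carbon chloro cannot be told apart from either methyl or trifluoromethyl, even though those two groups do differ by more than the scatter. So far, this position has taken all three groups with no step larger than modest, which the single earlier step could not show. Nothing shown here gives a measured reason for these numbers.

From the compounds shown here alone, it remains open how this carbon would respond to a different kind of group, such as an amine, a carboxylic acid or a longer chain. All three compounds share the rest of the core, so it is also unknown whether these exchanges would give similar steps on a changed core.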